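A few compounds are considered here, and "the series" means these few. Any claim that something is new, unique, unknown or untested is made for them only; others in the source may bear on it.

Compound 1 (`O=C(N/N=C/c1ccc([N+](=O)[O-])cc1)Nc1cc2c(Nc3ccc(F)c(Cl)c3)ncnc2cc1O[C@H]1CCOC1`) and compound 2 (`COc1cc(/C=N/NC(=O)Nc2cc3c(Nc4ccc(F)c(Cl)c4)ncnc3cc2O[C@H]2CCOC2)cc(OC)c1OC`) share one core and differ only in the group on a carbon with a double bond to nitrogen. In a functional assay on PC-3 cells (Homo sapiens) for cytotoxicity, read by MTT assay, with a stated time of 72 h (on this read-out higher numbers stand for weaker inhibition and lower numbers for stronger inhibition), compound 1 gives 33500 nM and compound 2 gives 29600 nM. Among the measured compounds shown here, compound 2 therefore lies within the scatter of compound 1, the only other compound measured so far.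

Compound 3 (`O=C(N/N=C/c1ccc(O)cc1O)Nc1cc2c(Nc3ccc(F)c(Cl)c3)ncnc2cc1O[C@H]1CCOC1`) has not yet been measured in this assay. Its difference from compound 2 is 2,4-dihydroxyphenyl in place of 3,4,5-trimethoxyphenyl on a carbon with a double bond to nitrogen: 2,4-dihydroxyphenyl in place of 3,4,5-trimethoxyphenyl, at the same carbon. For the measured compounds named here, only one measured step bears on this change. That step, a 1.1-fold lower number from compound 1 to compound 2 (0.05 log units; within the scatter), replaced 4-nitrophenyl with 3,4,5-trimethoxyphenyl at this carbon and did not move the number beyond the scatter. Going by the values given here, no measured compound carries a 2,4-dihydroxyphenyl group, so this evidence is thin and the range must stay wide. No shift in either direction beyond the scatter is expected, and the expected step is a 1.1-fold lower number from compound 2 to compound 3 (0.02 log units; within the scatter). The estimated value for compound 3 is 28000 nM, with an expected range from 10000 nM to 70000 nM.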

Compound 3, half-maximal inhibitory concentration: 7540 nM
Compound 3: the middle estimate sits 3.7-fold (0.57 log units) above what was measured; measured number outside the range, below it.
By their numbers in this assay, from the lowest: compound 3; then compounds 2 and 1 (each within the scatter of the next).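

In this assay, the group on the carbon with a double bond to nitrogen proved able to move the number beyond the scatter, which the earlier exchange, a 1.1-fold lower number from compound 1 to compound 2 (0.05 log units; within the scatter), had not shown. With 2,4-dihydroxyphenyl at this carbon the change is a 3.9-fold lower number from compound 2 to compound 3 (0.59 log units; beyond the scatter) and, against the nitro-bearing compound, a 4.4-fold lower number from compound 1 to compound 3 (0.65 log units; beyond the scatter), so the two earlier groups give much the same result and only the dihydroxy group stands apart from both. Compound 3 is also the only one of the three with hydrogen-bond donors on this ring, but nothing shown here ties the lower number to those donors or to any other feature of the group.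

The compounds shown leave open whether both hydroxy groups are needed, which 4-hydroxyphenyl and 2-hydroxyphenyl at the same carbon would help to settle. They also leave open whether the free hydroxy hydrogens matter at all, a question that 2,4-dimethoxyphenyl would address directly, or whether a 2,4-diaminophenyl group would serve equally well.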